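Half-life of a Nitro Analog with a Cyano Group

This account rests on a few compounds, and the source may have more. Where it says the series, first, only, none or still open, it means among the compounds named here.

Compound 1 `COc1c(O)cc2cc1Oc1ccc(cc1Cl)[C@@H](O)[C@@H](NC(=O)OC(C)(C)C)C(=O)N[C@@H](C#N)C(=O)N[C@H]2C(=O)OC(C)(C)C`: 0.39 h
Compound 2 `COc1c(O)cc2cc1Oc1ccc(cc1[N+](=O)[O-])[C@@H](O)[C@@H](NC(=O)OC(C)(C)C)C(=O)N[C@@H](CC(N)=O)C(=O)N[C@H]2C(=O)OC(C)(C)C`: 0.092 h

In an ADME assay for pharmacokinetics, at 140 degrees C (a lower number here means that the compound disappears faster, a higher number that the compound lasts longer), compound 2 gives the lower of the two numbers; compound 1 gives a number 0.39 h well beyond the scatter above it, though the two differ in two places at once. Compound 3 `COc1c(O)cc2cc1Oc1ccc(cc1[N+](=O)[O-])[C@@H](O)[C@@H](NC(=O)OC(C)(C)C)C(=O)N[C@@H](C#N)C(=O)N[C@H]2C(=O)OC(C)(C)C` differs from compound 2 in one place: cyano in place of carbamoylmethyl on a saturated ring carbon. For the measured compounds named here, no single step of this kind has been measured. The expected step of a 2.0-fold higher number from compound 2 to compound 3 (0.29 log units; within the scatter) is upward but modest, and may not exceed the scatter. Compound 3 is therefore estimated at 0.18 h, within 0.07 h to 0.45 h.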

Compound 3, half-life: 0.17 h
Beside the measured number, compound 3's estimate is 1.1-fold (0.02 log units) above it; the measured number falls inside the stated range.
By their numbers in this assay, from the lowest: compounds 2 and 3 (each within the scatter of the next); then compound 1.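

In this assay the swap of carbamoylmethyl for cyano on the saturated ring carbon next to the ring nitrogen gives a 1.8-fold higher number from compound 2 to compound 3 (0.27 log units; within the scatter) and so cannot be told apart from repeat measurements. The other single change, nitro in place of chloro on an aromatic carbon, gives a 2.3-fold lower number from compound 1 to compound 3 (0.36 log units; beyond the scatter) and is the only one of the two that clears the scatter. Nothing available here bears on the cause of either step.

Going by these compounds, whether an amine, a carboxylic acid or a longer chain on this ring carbon would shift the half-life beyond the scatter remains open. Also open, on these data alone, is whether nitro in place of chloro gives a similar step when carbamoylmethyl sits on that carbon.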